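Adding an isopropyl to compound 2

The source may report more compounds than this note shows. Statements on the series, on what has been measured and on what is new or still open speak of the compounds shown alone.

In a functional assay on HL-60 cells (Homo sapiens) for inhibition, read by CCK-8 assay, with a stated time of 48 h (on this read-out lower numbers stand for stronger inhibition and higher numbers for weaker inhibition), compound 2 `COc1ccc(Oc2ccccc2-c2ccsc2S(=O)(=O)NCCNC(=S)Nc2cc(C(F)(F)F)cc(C(F)(F)F)c2)cc1OC` gives 2800 nM and compound 3 `Cc1ccc(-c2ccsc2S(=O)(=O)NCCNC(=S)Nc2ccc([N+](=O)[O-])cc2)c(Oc2ccc(O)c(O)c2)c1` gives 2900 nM. These two numbers lie within the scatter of each other, so neither can be ranked ahead. Compound 1 `O=S(=O)(NCCNC(=S)Nc1cc(C(F)(F)F)cc(C(F)(F)F)c1)c1ccc(-c2ccccc2OCc2cccc(O)c2)s1` gives only a limit of the assay, > 50000 nM.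

Compound 4 `COc1ccc(Oc2ccc(C(C)C)cc2-c2ccsc2S(=O)(=O)NCCNC(=S)Nc2cc(C(F)(F)F)cc(C(F)(F)F)c2)cc1OC` differs from compound 2 by one change, isopropyl in place of hydrogen on an aromatic carbon, para to a 3,4-dimethoxyphenoxy group. Going by the values given here, no measured pair here differs in one place, so this change has no direct precedent. The expected step of a 1.4-fold lower number from compound 2 to compound 4 (0.15 log units; within the scatter) is modest, leaning slightly towards stronger inhibition, though it may stay within the scatter. Compound 4 is expected near 2000 nM, with an estimated range of 700 nM to 6000 nM.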

Compound 4, half-maximal inhibitory concentration: 6900 nM
For compound 4 the middle estimate is 3.5-fold (0.54 log units) below the measured one; measured number above the stated range.
By their numbers in this assay, from the lowest: compounds 2 and 3 (each within the scatter of the next); then compound 4. At a limit, above all of these: compound 1.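

Isopropyl in place of hydrogen gives the first step read at this position in this assay: a 2.5-fold higher number from compound 2 to compound 4 (0.39 log units; beyond the scatter), so the change weakens inhibition. This aromatic carbon, para to a 3,4-dimethoxyphenoxy group, therefore does not accept the added isopropyl without a loss. That rests on a single pair of compounds and does not extend to other groups or other cores.

Going by these compounds, whether an amine or a carboxylic acid at this carbon would also weaken inhibition remains open. Nothing measured here explains the step.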